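This account rests on a few compounds, and the source may have more. Where it says the series, first, only, none or still open, it means among the compounds named here.

The three measured compounds share one core and differ only in the group on one aromatic carbon. Compound 1 `Cc1ccccc1Cc1cnc(N)nc1N` gives 29500 nM in an assay for inhibition of Dihydrofolate reductase (Gallus gallus); on this read-out lower numbers stand for stronger inhibition and higher numbers for weaker inhibition. Compound 2 `CCCCOc1ccccc1Cc1cnc(N)nc1N` gives 8710 nM in this assay. Compound 3 `Nc1ncc(Cc2ccccc2O)c(N)n1` gives 89100 nM in this assay, the highest of the three numbers; its nearest neighbour is compound 1 and its furthest is compound 2. The steps between them read a 3.4-fold lower number from compound 1 to compound 2 (0.53 log units; beyond the scatter) and a 3.0-fold higher number from compound 1 to compound 3 (0.48 log units; beyond the scatter), and, most relevant here, a 10-fold higher number from compound 2 to compound 3 (1.01 log units; beyond the scatter). Compound 4 `C=CCOc1ccccc1Cc1cnc(N)nc1N` has not yet been measured. It differs from compound 3 by allyl in place of hydrogen on an oxygen on an aromatic ring. The change is the reverse of the step from compound 2 to compound 3, which was large, and an allyl rather than a butyl now enters on the oxygen, so a large step towards lower numbers is expected in this assay, though somewhat smaller than that one, because of a 10-fold higher number from compound 2 to compound 3 (1.01 log units; beyond the scatter). For compound 4 the expected step is a 5.9-fold lower number from compound 3 to compound 4 (0.77 log units; beyond the scatter), and the estimate is 15000 nM, with a range from 5000 nM to 40000 nM.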

Compound 4, inhibition constant: 21400 nM
The estimate for compound 4 lay 1.4-fold (0.15 log units) below the measured number, and the stated range covers the measured number.
By their numbers in this assay, from the lowest: compound 2; then compounds 4 and 1 (each within the scatter of the next); then compound 3.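

In (this assay) replacing the hydrogen on the oxygen with allyl lowers the number (a 4.2-fold lower number from compound 3 to compound 4 (0.62 log units; beyond the scatter)), so the direction seen with butyl on this oxygen also holds for a chain with a double bond. The two chains are not equivalent, as allyl stops short of butyl (a 2.5-fold higher number from compound 2 to compound 4 (0.39 log units; beyond the scatter)), while allyloxy and methyl on the aromatic carbon cannot be told apart (a 1.4-fold lower number from compound 1 to compound 4 (0.14 log units; within the scatter)). Nothing available accounts for these differences.

As far as these compounds go, it remains open whether a longer chain or a benzyl group on the oxygen would lower the number further than butyl does. From the compounds shown here alone, it is also open whether an amine on the same aromatic carbon would behave like hydroxy or like the chains joined through oxygen.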